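Swapping the halophenyl on a quinazoline thiosemicarbazide

The source may hold more compounds than are shown below. What is called first, only, known or untested is meant among the compounds shown, and "the series" means these compounds.

Compound 3 `O=C(NC(=S)NNc1ncnc2ccccc12)c1ccc(F)cc1` is the starting point of this comparison. Within the data shown here, in a functional assay on MGC-803 cells (Homo sapiens) for cytotoxicity, read by MTT assay, with a stated time of 72 h (on this read-out higher numbers stand for weaker inhibition and lower numbers for stronger inhibition), compound 3 gives 3600 nM, which stands second highest of the three numbers measured so far. Compound 1 `COc1cc2ncnc(NNC(=S)NC(=O)c3ccccc3OC)c2cc1OC` gives 1590 nM in this assay, and compound 2 `COc1cc2ncnc(NNC(=S)NC(=O)c3ccc(F)cc3)c2cc1OC` gives 8300 nM. The only single-change step among these three is a 5.2-fold higher number from compound 1 to compound 2 (0.72 log units; beyond the scatter), and it touches the same aryl group on the carbonyl carbon that is changed here.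

Compound 4 `O=C(NC(=S)NNc1ncnc2ccccc12)c1cccc(Cl)c1` differs from compound 3 by 3-chlorophenyl in place of 4-fluorophenyl on a carbonyl carbon. Among the measured compounds shown here, no measured pair shows a halogen moved from one ring position to another, so the step from compound 1 to compound 2 is the only guide to how much this part of the molecule can shift the number, and it was modest. On that basis compound 4 is expected to sit close to compound 3, with a 1.2-fold lower number from compound 3 to compound 4 (0.08 log units; within the scatter) as the expected step. The estimate for compound 4 is therefore 3000 nM, within a range of 900 nM to 10000 nM.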

Compound 4, half-maximal inhibitory concentration: 4540 nM
Compound 4: middle estimate off by 1.5-fold (0.18 log units), on the low side; the measured number falls inside the stated range.
By their numbers in this assay, from the lowest: compound 1; then compounds 3, 4 and 2 (each within the scatter of the next, the first and the last beyond it).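

Within this assay, the exchange of 4-fluorophenyl for 3-chlorophenyl on the carbonyl carbon gives a 1.3-fold higher number from compound 3 to compound 4 (0.10 log units; within the scatter) and so leaves the number unchanged within the scatter. The earlier step at this place, a 5.2-fold higher number from compound 1 to compound 2 (0.72 log units; beyond the scatter) on a different core, lay beyond the scatter, so this place does not respond to every exchange: one halophenyl can stand in for the other here with no clear difference, while the pair with 2-methoxyphenyl does differ. Nothing in the data gives a reason for this small step.

The halogen and its place on the ring change together in this step, and the compounds shown do not separate the two. On these data alone, how an amine or a carboxylic acid on this ring, or a longer chain in place of the ring, would affect the number also stays open.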